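Phenethyl ether on the chlorinated quinoline-type core

The source may hold more compounds than are shown below. What is called first, only, known or untested is meant among the compounds shown, and "the series" means these compounds.

Measured in a functional assay on NCI-H1650 cells (Homo sapiens) for cytotoxicity, read by MTT assay, with a stated time of 48 h; a higher number here means a weaker inhibitor, a lower number a stronger inhibitor:
- compound 1 `CCCCOc1ccc2c(Cl)ccnc2c1` gives 2570 nM
- compound 2 `CCCCCCCCOc1ccc2c(Cl)ccnc2c1` gives 3240 nM
- compound 3 `CCOc1ccc2c(Cl)ccnc2c1` gives 3340 nM

Compound 3 is the shortest ether of the three and its number sits together with those of compound 1 and compound 2: the step of a 1.3-fold higher number from compound 1 to compound 3 (0.11 log units; within the scatter) and the step of a 1.0-fold higher number from compound 2 to compound 3 (0.01 log units; within the scatter) are both within the scatter, so the three compounds cannot be told apart in this assay.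

Compound 4 `Clc1ccnc2cc(OCCc3ccccc3)ccc12` is the next variation of the same ether chain: phenyl in place of hydrogen on a saturated chain carbon, two bonds along the chain from an oxygen on an aromatic ring. The two measured steps that touch this position, a 1.0-fold higher number from compound 2 to compound 3 (0.01 log units; within the scatter) and a 1.3-fold higher number from compound 1 to compound 3 (0.11 log units; within the scatter), show that removing hexyl or ethyl from the chain carbon two bonds along from the oxygen changed nothing beyond the scatter, and the step of a 1.3-fold higher number from compound 1 to compound 2 (0.10 log units; within the scatter), further out along the chain, was equally flat. A phenyl at this position is a different kind of group from those alkyls, so the measured steps bear on it only loosely, but nothing in them points to a move in either direction. Compound 4 is therefore expected to give about 3000 nM in this assay, within 1200 nM to 8000 nM, an expected step of a 1.1-fold lower number from compound 3 to compound 4 (0.05 log units; within the scatter) from compound 3.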

Compound 4, half-maximal inhibitory concentration: 2300 nM
For compound 4 the middle estimate is 1.3-fold (0.12 log units) above the measured one, and the stated range covers the measured number.
By their numbers in this assay, from the lowest: compounds 4, 1, 2 and 3 (each within the scatter of the next).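

In this assay, the phenyl on the saturated chain carbon, two bonds along the chain from an oxygen on an aromatic ring, brings the first aromatic ring to this position, and the step of a 1.5-fold lower number from compound 3 to compound 4 (0.16 log units; within the scatter) shows that adding it does not move the number beyond what repeated measurements would give. The comparisons with the alkyl ethers, a 1.4-fold lower number from compound 2 to compound 4 (0.15 log units; within the scatter) and a 1.1-fold lower number from compound 1 to compound 4 (0.05 log units; within the scatter), show the same, so phenyl in place of hexyl or ethyl cannot be told apart from those chains, and the position has so far responded neither to chain length nor to this change from an alkyl group to an aromatic ring. No independent evidence bears on why all four compounds stay together.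

The compounds shown leave open whether any group at this position can separate itself from the others, for instance an amine or a carboxylic acid at the end of the chain, or a phenyl carrying a methoxy or a fluorine. They also leave open whether the chlorine on the shared core matters to the number, since it stays the same throughout, and an amine in its place would be a different test.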